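Z to E at the double bond of compound 3

The source may report more compounds than this note shows. Statements on the series, on what has been measured and on what is new or still open speak of the compounds shown alone.

In a functional assay on T98G cells (Homo sapiens) for cytotoxicity, read by MTT assay, with a stated time of 48 h (a lower number here means a stronger inhibitor, a higher number a weaker inhibitor), compound 3 `C/C(=N/NC(=S)Nc1ccccc1[N+](=O)[O-])c1ccccn1` gives 6.61 nM. Compound 1 `CC(=NNC(=S)Nc1ccccc1[N+](=O)[O-])c1ccccn1` gives 6.6 nM, level with compound 3 within the scatter. Compound 2 `C/C(=N\NC(=S)Nc1ccccc1Cl)c1ccccn1` gives 1.1 nM, a lower number than compound 3 and beyond the scatter. Compound 3 therefore sits with compound 1 at the high end of the three numbers.

The next compound is compound 4 `C/C(=N\NC(=S)Nc1ccccc1[N+](=O)[O-])c1ccccn1`. Its relation to compound 3 is as follows: the two compounds have the same atoms and bonds and differ only in configuration as drawn: 1 of 1 stereo elements differ; a double bond is drawn Z in compound 3 and E in compound 4. Nothing leaves and nothing enters.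

For the measured compounds named here, one measured step bears on this change: a 1.0-fold higher number from compound 1 to compound 3 (0.00 log units; within the scatter), within the scatter. It concerns (the fact that one of compounds 1 and 3 is drawn with a defined configuration and the other without, at the place where they differ). Going by the values given here, that step sets an undefined drawing against a Z drawing, so it gives no direct measure of Z against E. No measured pair isolates that change. On this thin evidence, no step beyond the scatter is expected in this assay, and no direction is favoured with any confidence. The expected size is a 1.1-fold lower number from compound 3 to compound 4 (0.04 log units; within the scatter). The range is kept wide to leave room for a real difference in either direction.

The estimate for compound 4 is 6 nM, with an expected range of 2 nM to 14 nM.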

Compound 4, half-maximal inhibitory concentration: 6.61 nM
Compound 4: middle estimate off by 1.1-fold (0.04 log units), on the low side, within the range that was stated.
By their numbers in this assay, from the lowest: compound 2; then compounds 1, 3 and 4 (each within the scatter of the next).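

For the compounds shown here, the Z-to-E change at this double bond now has a direct reading in this assay, where the earlier compounds set only an undefined drawing against a Z drawing. That reading is no change at the digits printed from compound 3 to compound 4 (within the scatter), and it is the one step here that isolates Z against E: the fact that compounds 3 and 4 differ only in the configuration as drawn

The undefined drawing also stays level with the E drawing, with a 1.0-fold higher number from compound 1 to compound 4 (0.00 log units; within the scatter), so for the nitro compounds all three drawings of the double bond give the same reading within the scatter. Going by these compounds alone, compound 4 also gives the first comparison of nitro in place of chloro with the double bond drawn alike in both compounds, and this exchange, unlike the change in configuration, does move the number: a 6.0-fold higher number from compound 2 to compound 4 (0.78 log units; beyond the scatter).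

The compounds shown leave open whether the double bond makes as little difference with chloro on the aromatic ring as it does with nitro. They also leave open how a methoxy group or an amine in place of nitro would read against these two groups in this assay.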